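The compounds below may be only part of what the source reports. "The series", "measured", "known", "first", "only" and "open" are said of these compounds alone.

Compound 1 `CN1CCN(c2cn(S(=O)(=O)c3ccccc3)c3ccccc23)CC1` carries a 4-methylpiperazin-1-yl group on its core. In an assay on isolated protein for displacement of a labelled ligand from 5-hydroxytryptamine receptor 6 (Homo sapiens), read by scintillation counting, with a stated time of 1 h (on this read-out lower numbers stand for stronger inhibition and higher numbers for weaker inhibition), compound 1 gives 4 nM. Compound 2 `CC(=O)N1CCN(c2cn(S(=O)(=O)c3ccccc3)c3ccccc23)CC1` is built on the same core, with one change: acetyl in place of methyl on an amine nitrogen in a ring. In this assay compound 2 gives 97 nM, so that a 24-fold higher number from compound 1 to compound 2 (1.38 log units; beyond the scatter).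

Compound 3 `CN1CCN(c2ccc3c(ccn3S(=O)(=O)c3ccccc3)c2)CC1` is made of the same atoms as compound 1, joined differently, so that the 4-methylpiperazin-1-yl group sits on a different part of the core; how the two cores differ is not broken down here. In this assay compound 3 gives 27 nM, a weaker binder than compound 1 but a stronger one than compound 2.

Compound 4 `CC(=O)N1CCN(c2ccc3c(ccn3S(=O)(=O)c3ccccc3)c2)CC1` has not yet been measured. It differs from compound 3 in the same way that compound 2 differs from compound 1: acetyl in place of methyl on an amine nitrogen in a ring. The surroundings of the change are described in the same words for both pairs, so the change is the same, made on the core of compound 3 instead of the core of compound 1.

The change has been seen only once so far, on a different core. Taking that one step as the guide, the number for compound 4 is expected to be 500 nM, with a likely range from 150 nM to 2000 nM, because of a 24-fold higher number from compound 1 to compound 2 (1.38 log units; beyond the scatter). That estimate means that the expected step of a 19-fold higher number from compound 3 to compound 4 (1.27 log units; beyond the scatter) is of about the same size as the earlier one, and the estimate rests on one pair only.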

Compound 4, inhibition constant: 4850 nM
The estimate for compound 4 lay 9.7-fold (0.99 log units) below the measured number; measured number above the stated range.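

In this assay, putting acetyl in place of methyl on the ring nitrogen weakens binding on both cores, and the new case is a 180-fold higher number from compound 3 to compound 4 (2.25 log units; beyond the scatter). The direction of the change therefore carries over from one core to the other, but its size does not: the same change on two cores in this assay, a 24-fold higher number (1.38 log units; beyond the scatter) from compound 1 to compound 2 and a 180-fold higher number (2.25 log units; beyond the scatter) from compound 3 to compound 4, 7.4-fold (0.87 log units) apart, beyond the scatter of two such steps So in this series, a step measured on one core gives a reliable sign for the same change on the other core, but not a reliable size, and these two pairs show neither why the size differs nor how a third core would behave.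

The compounds shown leave open how other groups on that same ring nitrogen, such as a bare hydrogen, ethyl or a longer acyl chain, would behave on each of the two cores, and whether the gap between the cores would persist with them. They also leave open whether the larger step belongs to the position of the piperazine ring on the core, since the two cores are compared only through this one pair of groups.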